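Removing One Methoxy Group and Growth Inhibition

The source may hold more compounds than are shown below. What is called first, only, known or untested is meant among the compounds shown, and "the series" means these compounds.

Three compounds were measured in a functional assay on SW-620 cells (Homo sapiens) for inhibition, read by sulforhodamine B assay, with a stated time of 48 h; on this read-out lower numbers stand for stronger inhibition of growth and higher numbers for weaker inhibition of growth:

compound 1 `COc1cc(-c2cc(/C=C/C(=O)c3ccc(N)cc3)[nH]n2)cc(OC)c1OC` gives 6370 nM
compound 2 `COc1ccc(-c2cc(/C=C/C(=O)c3ccc(N)cc3)[nH]n2)cc1OC` gives 6940 nM
compound 3 `COc1cc(C(=O)/C=C/c2cc(-c3cc(OC)c(OC)c(OC)c3)n[nH]2)cc(OC)c1OC` gives 3080 nM

Compound 1 and compound 2 differ by hydrogen in place of methoxy on an aromatic carbon, and this gives a 1.1-fold higher number from compound 1 to compound 2 (0.04 log units; within the scatter). Compound 3 carries a different core; the difference between the two cores is not broken down here. Compound 4 `COc1ccc(-c2cc(/C=C/C(=O)c3cc(OC)c(OC)c(OC)c3)[nH]n2)cc1OC` is derived from compound 3 by hydrogen in place of methoxy on an aromatic carbon, the same change as between compound 1 and compound 2. Because the earlier step was a 1.1-fold higher number from compound 1 to compound 2 (0.04 log units; within the scatter), compound 4 is expected to stay close to compound 3, and the expected step in this assay is a 1.1-fold higher number from compound 3 to compound 4 (0.04 log units; within the scatter). The estimate for compound 4 is 3400 nM, with a range from 1700 nM to 7000 nM.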

Compound 4, concentration for total growth inhibition: 4160 nM
Estimate against measurement, compound 4: 1.2-fold (0.09 log units) below; low and high end bracket the measured number.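

In this assay, hydrogen in place of methoxy on an aromatic carbon gives a 1.4-fold higher number from compound 3 to compound 4 (0.13 log units; within the scatter) on the core of compound 3, so the step remains within the scatter there too. Set side by side, the two steps agree: the same change on two cores in this assay, a 1.1-fold higher number (0.04 log units; within the scatter) from compound 1 to compound 2 and a 1.4-fold higher number (0.13 log units; within the scatter) from compound 3 to compound 4, 1.2-fold (0.09 log units) apart, within the scatter of two such steps. This shows that, on these two cores and in this one assay, the change carries over as a step within the scatter; it does not show that the same would hold on any other core or in any other assay.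

The compounds shown leave open what a hydroxyl group, a fluorine atom or a longer chain such as ethoxy would do in the place of this methoxy group.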